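One added methyl on the chain of compound 3

The compounds below may be only part of what the source reports. "The series", "measured", "known", "first", "only" and "open" are said of these compounds alone.

In a physicochemical assay for solubility, read by HPLC, in phosphate buffer, with a stated time of 24 h, at pH 7.4, tested at 100 uM (a lower number here means a less soluble compound, a higher number a more soluble compound), compound 3 (`Cc1ccc(Nc2c(NCCCCCC(=O)NO)c(=O)c2=O)cc1`) gives 8100000 nM as the lowest of three numbers, with compound 1 (`O=C(CCCCCNc1c(NCc2ccccc2)c(=O)c1=O)NO`) at 75000000 nM and compound 2 (`O=C(CCCCCNc1c(NC2CCCCC2)c(=O)c1=O)NO`) at 91000000 nM for comparison. Compound 4 (`Cc1ccc(Nc2c(NC(C)CCCCC(=O)NO)c(=O)c2=O)cc1`) carries methyl in place of hydrogen on a saturated chain carbon bound to a nitrogen on an aromatic ring and a saturated chain carbon. For the measured compounds named here, no measured step touches that chain. Swapping whole ring groups gave sizeable steps (a 9.3-fold lower number from compound 1 to compound 3 (0.97 log units; beyond the scatter) and an 11-fold lower number from compound 2 to compound 3 (1.05 log units; beyond the scatter)), while another swap stayed within the scatter (a 1.2-fold higher number from compound 1 to compound 2 (0.08 log units; within the scatter)). Compound 3 (8100000 nM) remains the anchor: a single methyl is a much smaller change than those swaps, so in this assay no step beyond the scatter is expected (a 1.1-fold higher number from compound 3 to compound 4 (0.05 log units; within the scatter)). Compound 4 is estimated at 9000000 nM, with an expected range from 3500000 nM to 25000000 nM for the measurement.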

Compound 4, solubility: 83000000 nM
Beside the measured number, compound 4's estimate is 9.2-fold (0.96 log units) below it; the measured number lies above the stated range.
By their numbers in this assay, from the lowest: compound 3; then compounds 1, 4 and 2 (each within the scatter of the next).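

In this assay the saturated chain carbon bound to a nitrogen on an aromatic ring proves sensitive: methyl in place of hydrogen there gives a 10-fold higher number from compound 3 to compound 4 (1.01 log units; beyond the scatter) in a single step. One added carbon on the chain thus moves this read-out about as far as the earlier swaps of whole ring groups did. Nothing available explains this rise. On these data alone, whether ethyl on this carbon moves the number the same way remains open, as does whether the same methyl would act alike in compound 1 or compound 2.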